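Swapping the aryl group on the sulfonate ester for an iodinated ring

The source may report more compounds than this note shows. Statements on the series, on what has been measured and on what is new or still open speak of the compounds shown alone.

Compound 1 `Cc1ccc(OS(=O)(=O)c2ccc(N3CCN(C)C3=O)cc2)c(C)c1` gives the lowest number of the three measured compounds in a functional assay on MCF7 cells (Homo sapiens) for antiproliferative activity, read by sulforhodamine B assay, with a stated time of 48 h (on this read-out higher numbers stand for weaker inhibition and lower numbers for stronger inhibition), at 2500 nM; compound 3 `COc1cccc(OS(=O)(=O)c2ccc(N3CCN(C)C3=O)cc2)c1` gives 3000 nM, a number that falls inside the scatter of that of compound 1, while compound 2 `Cc1cccc(OS(=O)(=O)c2ccc(N3CCN(C)C3=O)cc2)c1` gives 5100 nM, a number that lies outside it. Compound 4 `CN1CCN(c2ccc(S(=O)(=O)Oc3cccc(I)c3)cc2)C1=O` differs from compound 1 by 3-iodophenyl in place of 2,4-dimethylphenyl on an oxygen. The two steps that bear on this exchange both replace the 2,4-dimethylphenyl with a differently substituted phenyl: a 2.0-fold higher number from compound 1 to compound 2 (0.31 log units; beyond the scatter) and a 1.2-fold higher number from compound 1 to compound 3 (0.08 log units; within the scatter). Neither moved the number lower, so for compound 4 a modestly higher number is expected, a 1.6-fold higher number from compound 1 to compound 4 (0.20 log units; within the scatter). Compound 4 is therefore estimated at 4000 nM in this assay, with a likely range from 2000 nM to 9000 nM.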

Compound 4, half-maximal inhibitory concentration: 560 nM
Beside the measured number, compound 4's estimate is 7.1-fold (0.85 log units) above it; the measured number lies below the stated range.
By their numbers in this assay, from the lowest: compound 4; then compounds 1, 3 and 2 (each within the scatter of the next, the first and the last beyond it).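

In this assay, changing the aryl group on this oxygen can lower the number, which neither earlier exchange did: 3-iodophenyl in place of 2,4-dimethylphenyl gives (a 4.5-fold lower number from compound 1 to compound 4 (0.65 log units; beyond the scatter)). The iodo group also stands apart from the other single substituents, with iodo in place of methoxy giving (a 5.4-fold lower number from compound 3 to compound 4 (0.73 log units; beyond the scatter)) and iodo in place of methyl giving (a 9.1-fold lower number from compound 2 to compound 4 (0.96 log units; beyond the scatter)). No measurement here says why iodo has this effect.

On these data alone, whether a bromo or chloro group, an amine or a carboxylic acid on this ring would reach a similarly low number remains open. So does whether moving the iodo group elsewhere on the ring would keep the gain.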